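The source may hold more compounds than are shown below. What is called first, only, known or untested is meant among the compounds shown, and "the series" means these compounds.

Measured in a functional assay on HeLa cells (Homo sapiens) for antiproliferative activity, read by MTT assay, with a stated time of 48 h; a higher number here means a weaker inhibitor, a lower number a stronger inhibitor:
Compound 1 `Clc1ccc(-c2nn(-c3ccccc3)cc2-c2nc3cc(Cl)ccc3[nH]2)cc1`: 1630 nM
Compound 2 `COc1ccc(-c2nn(-c3ccccc3)cc2-c2nc3cc(F)ccc3[nH]2)cc1`: 1740 nM

Compound 2 stands level with compound 1, since their two values lie within the usual scatter of each other. Compound 3 `COc1ccc(-c2nn(-c3ccccc3)cc2-c2nc3cc(Cl)ccc3[nH]2)cc1` keeps the core of compound 2 and differs from it at one place, (chloro in place of fluoro on an aromatic carbon), with chloro in place of fluoro on an aromatic carbon. Among the measured compounds shown here, no two measured compounds differ at this place alone, so the data give no direct size for this change. With so little to go on, no shift beyond the scatter is expected in this assay, in either direction. The estimated step is a 1.2-fold lower number from compound 2 to compound 3 (0.06 log units; within the scatter), and it is expected to stay within the scatter. For compound 3 the estimated half-maximal inhibitory concentration is 1500 nM, with an expected range from 700 nM to 3200 nM.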

Compound 3, half-maximal inhibitory concentration: 1290 nM
For compound 3 the middle estimate is 1.2-fold (0.07 log units) above the measured one, within the range that was stated.
By their numbers in this assay, from the lowest: compounds 3, 1 and 2 (each within the scatter of the next).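

Among the compounds shown here, compound 3 gives the first direct reading of this place: in this assay, chloro in place of fluoro on an aromatic carbon of the fused two-ring system gives a 1.3-fold lower number from compound 2 to compound 3 (0.13 log units; within the scatter), so the two halogens stand level here. It also gives a direct reading of a second place, where methoxy in place of chloro on an aromatic carbon gives a 1.3-fold lower number from compound 1 to compound 3 (0.10 log units; within the scatter), and these two groups also stand level. Neither single change among these three compounds reaches beyond the scatter, though each place has been read only once, with one pair of groups.

The compounds shown leave open whether an amine or a carboxylic acid at either place would shift the number beyond the scatter. Nothing available accounts for how closely these values agree.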